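The source may report more compounds than this note shows. Statements on the series, on what has been measured and on what is new or still open speak of the compounds shown alone.

Measured compounds:
compound 1 `O=C1N=C(N2N=C(c3ccccc3)CC2c2ccccc2O)S/C1=C1/C(=O)Nc2ccccc21`, 17800 nM
compound 2 `O=C1N=C(N2N=C(c3ccccc3)CC2c2ccccc2O)S/C1=C1/C(=O)Nc2ccc(Br)cc21`, 630 nM
compound 3 `COc1ccc(C2=NN(C3=NC(=O)/C(=C4\C(=O)Nc5ccc(Cl)cc54)S3)C(c3ccc(Cl)cc3)C2)cc1`, 460 nM

In a functional assay on cells (Cancer cell lines, Homo sapiens) for cytotoxicity, read by sulforhodamine B assay, with a stated time of 48 h (on this read-out higher numbers stand for weaker inhibition of growth and lower numbers for stronger inhibition of growth), compound 1 gives the highest number of the three, so it inhibits growth least. Compound 2 differs from it in one place and shows a 28-fold lower number from compound 1 to compound 2 (1.45 log units; beyond the scatter). Compound 3 differs in several places, and its value is simply lower than that of compound 1.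

Compound 4 `CN(C)c1ccc(C2CC(c3ccccc3)=NN2C2=NC(=O)/C(=C3\C(=O)Nc4ccccc43)S2)cc1` differs from compound 1 by 4-(dimethylamino)phenyl in place of 2-hydroxyphenyl on a saturated ring carbon. Among the measured compounds shown here, no measured step touches this place; the one step that exists concerns a bromo on an aromatic carbon, elsewhere in the shared core. Since the only data at this position come from compound 3, whose other changes cannot be separated, a modest decrease is expected at best, with wide uncertainty. For compound 4 the expected step is a 2.0-fold lower number from compound 1 to compound 4 (0.30 log units; within the scatter), giving an estimated 9000 nM in this assay, ranging from 2500 nM to 30000 nM.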

Compound 4, concentration for total growth inhibition: 18800 nM
For compound 4 the middle estimate is 2.1-fold (0.32 log units) below the measured one, and the stated range covers the measured number.
By their numbers in this assay, from the lowest: compounds 3 and 2 (each within the scatter of the next); then compounds 1 and 4 (each within the scatter of the next).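

In this assay, among the compounds shown here, placing 4-(dimethylamino)phenyl instead of 2-hydroxyphenyl on the saturated ring carbon gives a 1.1-fold higher number from compound 1 to compound 4 (0.02 log units; within the scatter) and is the first clean reading at this position. This single change removes the hydrogen-bond donor and adds heavy atoms, yet the read-out stays within the scatter. No measurement here explains why the two groups read alike.

Still open, on these data alone, is whether a phenyl ring carrying a carboxylic acid or a primary amine would also read alike at this position. Also open, as far as these compounds go, is whether bromo would lower the number for compound 4 as it does for compound 2.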